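Series notes: methoxy in place of chloro, antiproliferative read-out

The source may hold more compounds than are shown below. What is called first, only, known or untested is meant among the compounds shown, and "the series" means these compounds.

Measured compounds:
compound 1 `FC(F)(F)c1ccc(C2CC(c3ccc(Cl)cc3)=NN2c2ccc(-c3ccccc3)nn2)cc1` — > 100000 nM, a limit
compound 2 `COc1ccc(C2CC(c3ccc(Cl)cc3)=NN2c2ccc(-c3ccccc3)nn2)c(OC)c1` — > 100000 nM, a limit

In a functional assay on A549 cells (Homo sapiens) for antiproliferative activity, read by MTT assay, with a stated time of 24 h (on this read-out lower numbers stand for stronger inhibition and higher numbers for weaker inhibition), compound 1 gives > 100000 nM, which is a limit of the assay and not a number. In this assay compound 2 gives > 100000 nM, likewise only a limit. For the measured compounds named here, both values sit at the limit of > 100000 nM in this assay, at which 2 of the 2 values shown sit, so the single recorded step, a step that the two limits leave unreadable from compound 1 to compound 2, has no readable size. Compound 2 therefore stands at the limit, with no number to place it against.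

Compound 3 `COc1ccc(C2=NN(c3ccc(-c4ccccc4)nn3)C(c3ccc(OC)cc3OC)C2)cc1` differs from compound 2 by methoxy in place of chloro on an aromatic carbon. Going by the values given here, no measured step bears on this change, and the one step recorded concerns another position and is itself unreadable. With nothing to shift the picture, compound 3 is expected to stay at the limit, and the expected step that the limit leaves unreadable from compound 2 to compound 3 is estimated to lie within the scatter. The estimate for compound 3 is 150000 nM, with a range from 40000 nM to 600000 nM.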

Compound 3, half-maximal inhibitory concentration: 100000 nM
Compound 3: middle estimate off by 1.5-fold (0.18 log units), on the high side; the measured number falls inside the stated range.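

In this assay, for the compounds shown here, compound 3 gives 100000 nM, a plain number, so the change from 4-chlorophenyl to 4-methoxyphenyl, para to a large group, is the first to end on a readable value. That value still gives no sign of strong inhibition with methoxy at this place. The data show a number no higher from compound 2 to compound 3 (the limit leaves the size open) for this change. The step itself cannot be read, because its starting value is a limit: the limit of > 100000 nM in this assay, at which 2 of the 3 values shown sit.

As far as these compounds go, how far compound 2 really lies from compound 3 stays open, as does whether any group at this place can move the value clearly lower. The compounds shown say nothing about an amine or a carboxylic acid in place of methoxy on this aromatic carbon.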